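This account rests on a few compounds, and the source may have more. Where it says the series, first, only, none or still open, it means among the compounds named here.

Of the compounds shown here, three sharing one core have been measured in an assay on isolated protein for inhibition of serine/threonine-protein kinase Chk2 (Homo sapiens); a higher number here means a weaker inhibitor, a lower number a stronger inhibitor. Compound 1 `CC(C)c1ccc(O)c(-c2nc(N[C@H]3CCNC3)c3ccccc3n2)c1` gives 1700 nM, the highest of the three numbers. Compound 2 `CC(C)(O)[C@H]1C[C@H](Nc2nc(-c3cc(F)ccc3O)nc3ccccc23)CN1` gives 460 nM, and compound 3 `OC[C@H]1C[C@H](Nc2nc(-c3cc(F)ccc3O)nc3ccccc23)CN1` gives 81 nM. Going by the values given here, the only step between compounds that differ in a single place is a 5.7-fold lower number from compound 2 to compound 3 (0.75 log units; beyond the scatter); it concerns a substituent on the saturated ring, not the aromatic ring that separates compound 1 from the compound still to be measured.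

Compound 4 `Oc1ccc(C(F)(F)F)cc1-c1nc(N[C@H]2CCNC2)c2ccccc2n1` differs from compound 1 in one place: trifluoromethyl in place of isopropyl on an aromatic carbon. Among the compounds with values here, no measured pair in this set alters a group on that aromatic carbon, so neither the size nor the direction of the step can be read from a step of the same kind. The step from compound 2 to compound 3 shows only that exchanging one small substituent for another can move this assay by a modest amount, and it sits on a different part of the molecule. The step of a 1.1-fold lower number from compound 1 to compound 4 (0.05 log units; within the scatter) is therefore expected to fall within or only slightly beyond the scatter, with a wide margin of uncertainty in either direction. The estimate for compound 4 in this assay is 1500 nM, ranging from 400 nM to 5500 nM.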

Compound 4, half-maximal inhibitory concentration: 201 nM
The estimate for compound 4 lay 7.5-fold (0.87 log units) above the measured number; measured number outside the range, below it.
By their numbers in this assay, from the lowest: compound 3; then compound 4; then compound 2; then compound 1.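

In this assay, going by these compounds alone, the aromatic carbon para to a hydroxy group proves sensitive to its substituent: trifluoromethyl in place of isopropyl gives an 8.5-fold lower number from compound 1 to compound 4 (0.93 log units; beyond the scatter), the first step in this set to probe that position. A change at this carbon can therefore move the number beyond the scatter, as the exchange on a saturated ring carbon did in another part of the molecule, with a 5.7-fold lower number from compound 2 to compound 3 (0.75 log units; beyond the scatter). The step itself records only the direction and size of the change for this one exchange, and no measurement shown bears on what lies behind it.

On these data alone, with only isopropyl and trifluoromethyl compared directly at this carbon, it remains open where a nitrile, a methoxy group or a carboxylic acid there would fall in this assay, and so whether any trend runs across groups at this position. As far as these compounds go, it also remains open whether exchanging isopropyl for trifluoromethyl would give a similar step on a molecule carrying the hydroxymethyl-bearing saturated ring of compound 3, rather than the unsubstituted saturated ring of compound 1 and compound 4.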